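This account rests on a few compounds, and the source may have more. Where it says the series, first, only, none or still open, it means among the compounds named here.

In a functional assay on KBVIN cells (Homo sapiens) for antiproliferative activity, read by sulforhodamine B assay, with a stated time of 3 days (a lower number here means a stronger inhibitor of growth, a higher number a weaker inhibitor of growth), two compounds have been measured so far. Compound 1 (`O=C(Nc1cccc(Nc2ncc(F)c(Nc3ccc(F)cc3)n2)c1)c1ccncc1`) gives 4570 nM, and compound 2 (`COc1cc(NC(=O)c2cccc(Nc3ncc(F)c(Nc4ccc(F)cc4)n3)c2)cc(OC)c1`) gives 12700 nM. Compound 2 therefore stands highest of the pair, a gap beyond the usual scatter, which makes it the weaker inhibitor of growth. Within the data shown here, the two compounds differ in more than one place, so no single-change step is available as a guide. Compound 3 (`O=C(NCCO)c1cccc(Nc2ncc(F)c(Nc3ccc(F)cc3)n2)c1`) departs from compound 2 on an amide-type nitrogen: 2-hydroxyethyl in place of 3,5-dimethoxyphenyl on an amide-type nitrogen. Among the measured compounds shown here, with no measured precedent for this exchange, no step beyond the scatter is expected in this assay, although the uncertainty runs wide in both directions. The estimated change is a 1.2-fold higher number from compound 2 to compound 3 (0.07 log units; within the scatter). In this assay, the estimate for compound 3 is 15000 nM, with an expected range from 5000 nM to 40000 nM.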

Compound 3, concentration for 50% growth inhibition: 21400 nM
Compound 3: the middle estimate sits 1.4-fold (0.15 log units) below what was measured, and the stated range covers the measured number.
By their numbers in this assay, from the lowest: compound 1; then compounds 2 and 3 (each within the scatter of the next).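

On the amide-type nitrogen in this assay, the exchange of 3,5-dimethoxyphenyl for 2-hydroxyethyl gives a 1.7-fold higher number from compound 2 to compound 3 (0.23 log units; within the scatter), so at this position an open chain with no ring stays level with the aromatic group it replaces. The exchange on an aromatic carbon, (2-hydroxyethyl)carbamoyl in place of ((pyridin-4-yl)carbonyl)amino, is a larger step, a 4.7-fold higher number from compound 1 to compound 3 (0.67 log units; beyond the scatter), and leaves compound 1 with the lowest number of the three. No measurement offered alongside these compounds accounts for either step.

Going by these compounds, whether a longer chain, a dimethylamino group or a carboxylic acid at the end of the chain on this nitrogen would move the number remains open. So does whether an unsubstituted phenyl there would stay level with compound 2.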